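Shifting from pyridin-2-yl to pyridin-3-yl in compound 4

The source may report more compounds than this note shows. Statements on the series, on what has been measured and on what is new or still open speak of the compounds shown alone.

Of the compounds shown here, three with one shared core have been measured in an assay on HEK293 cells for agonist activity at Toll-like receptor 8 (Homo sapiens), read by a luciferase reporter, with a stated time of 6 h; a higher number here means that more compound is needed for the effect, a lower number that less compound is needed. Compound 1 `CCCCNc1nc(N)nc2c1CN(Cc1ccccc1)CC2` gives 0.06 uM in this assay. Compound 2 `CCCCNc1nc(N)nc2c1CN(Cc1ccc(OC)cc1)CC2` gives 0.08 uM. Compound 3 `CCCCNc1nc(N)nc2c1CN(Cc1ccccn1)CC2` gives 0.07 uM, the second highest of the three numbers, with compound 2 nearest and compound 1 furthest, both within the scatter. Compound 4 `CCCCNc1nc(N)nc2c1CN(Cc1cccnc1)CC2` differs from compound 3 in one place: pyridin-3-yl in place of pyridin-2-yl on a saturated chain carbon bound to an amine nitrogen in a ring. Within the data shown here, the steps that bear on this change are a 1.2-fold higher number from compound 1 to compound 3 (0.07 log units; within the scatter) and a 1.1-fold lower number from compound 2 to compound 3 (0.06 log units; within the scatter), while a 1.3-fold higher number from compound 1 to compound 2 (0.12 log units; within the scatter) also stays within the scatter. Among the measured compounds shown here, since every change at this place so far has stayed within the scatter, compound 4 is expected to show no change at the digits printed from compound 3 to compound 4 (within the scatter). Compound 4 is therefore estimated at 0.07 uM, within 0.035 uM to 0.14 uM.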

Compound 4, minimum effective concentration: 0.13 uM
For compound 4 the middle estimate is 1.9-fold (0.27 log units) below the measured one; measured number inside the range.
By their numbers in this assay, from the lowest: compounds 1, 3, 2 and 4 (each within the scatter of the next, the first and the last beyond it).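

Pyridin-3-yl in place of pyridin-2-yl gives a 1.9-fold higher number from compound 3 to compound 4 (0.27 log units; within the scatter) and so stays within the scatter, as does the change from 4-methoxyphenyl, a 1.6-fold higher number from compound 2 to compound 4 (0.21 log units; within the scatter) by comparison. Among these compounds, the change from phenyl, however, gives a 2.2-fold higher number from compound 1 to compound 4 (0.34 log units; beyond the scatter) and is the first step at this place to pass the scatter, though only modestly. Nothing measured here accounts for this step. Still open, on these data alone, is how pyridin-4-yl or a cyclohexyl group would read on this saturated chain carbon, and whether a longer chain in place of the butyl amine would shift these numbers.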